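A few compounds are considered here, and "the series" means these few. Any claim that something is new, unique, unknown or untested is made for them only; others in the source may bear on it.

Compound 1 `CCOC(=O)c1ccc(-c2nn(Cc3ccccc3F)c3ccccc23)cc1` gives > 10000 nM in a functional assay on cells (Platelet, Homo sapiens) for inhibition (a lower number here means a stronger inhibitor, a higher number a weaker inhibitor), and this is a limit of the assay rather than a number. Compound 2 `CCOC(=O)c1ccc(-c2nn(Cc3ccncc3)c3ccccc23)cc1` gives > 10000 nM in this assay, which is likewise only a limit. Going by the values given here, the one measured step is a step that the two limits leave unreadable from compound 1 to compound 2, so it offers no size to carry forward. What the two compounds share is the limit of > 10000 nM in this assay, at which 2 of the 2 values shown sit.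

Compound 3 `CCOC(=O)c1ccc(-c2nn(-c3ccoc3)c3ccccc23)cc1` keeps the core of compound 2 and alters the same substituent: furan-3-yl in place of (pyridin-4-yl)methyl on an aromatic nitrogen. In words, furan-3-yl stands in place of (pyridin-4-yl)methyl on an aromatic nitrogen. Among the compounds with values here, no measured compound carries a ring directly on that nitrogen, and so the data do not show what this change does. With two different groups on a methylene link both failing to yield a number, the working expectation is no readable gain in this assay, and a further limit is the likeliest report. The expected step is a step that the limit leaves unreadable from compound 2 to compound 3, an estimate that carries little information. For compound 3 the estimated value is 12000 nM, with an expected range from 4000 nM to 30000 nM.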

Compound 3, half-maximal inhibitory concentration: > 10000 nM
Compound 3 was reported as a limit; the forecaster's own chance of this, stated with the estimate: 85%; the middle value is on the limit's open side.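

In this assay compound 3 gives > 10000 nM, which is again a limit and not a number. Going by these compounds alone, no step among compound 1, compound 2 and compound 3 can be read, and what they share is this: the limit of > 10000 nM in this assay, at which 3 of the 3 values shown sit. The compounds shown leave open whether any group on that aromatic nitrogen gives a readable value in this assay.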